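The source may report more compounds than this note shows. Statements on the series, on what has been measured and on what is new or still open speak of the compounds shown alone.

Measured in a functional assay on MT4 cells (Homo sapiens); on this read-out higher numbers stand for lower toxicity in this test and lower numbers for higher toxicity in this test:
- compound 1 `CC(=O)NC1=CS(=O)(=O)O[C@@]12[C@@H](CO[Si](C)(C)C(C)(C)C)O[C@@H](n1cc(C)c(=O)n(C)c1=O)[C@@H]2O[Si](C)(C)C(C)(C)C`: 10700 nM
- compound 2 `Cc1cn([C@@H]2O[C@H](CO[Si](C)(C)C(C)(C)C)[C@@]3(OS(=O)(=O)C=C3NC(N)=O)[C@H]2O[Si](C)(C)C(C)(C)C)c(=O)n(C)c1=O`: 3700 nM
- compound 3 `COC(=O)CC(=O)NC1=CS(=O)(=O)O[C@@]12[C@@H](CO[Si](C)(C)C(C)(C)C)O[C@@H](n1cc(C)c(=O)n(C)c1=O)[C@@H]2O[Si](C)(C)C(C)(C)C`: 11900 nM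

Compound 3 gives 11900 nM, which lies within the scatter of compound 1, while compound 2 has the lowest number of the three.

Next in the series is compound 4 `COC(=O)C(=O)CNC1=CS(=O)(=O)O[C@@]12[C@@H](CO[Si](C)(C)C(C)(C)C)O[C@@H](n1cc(C)c(=O)n(C)c1=O)[C@@H]2O[Si](C)(C)C(C)(C)C`. It has the same atoms as compound 3, joined differently, with ((methoxycarbonyl)carbonyl)methyl in place of ((methoxycarbonyl)methyl)carbonyl on an amine nitrogen.

Among the compounds with values here, three measured steps bear on this change, though only indirectly. The closest in group size is a 1.1-fold higher number from compound 1 to compound 3 (0.05 log units; within the scatter), which stays within the scatter. The other two, a 2.9-fold lower number from compound 1 to compound 2 (0.46 log units; beyond the scatter) and a 3.2-fold higher number from compound 2 to compound 3 (0.51 log units; beyond the scatter), are modest. Within the data shown here, all three alter what sits on a carbonyl carbon, and none removes the carbonyl from the amine nitrogen, so the data hold no direct precedent for this change. Only the size of these steps can guide the expectation, which is for a small shift with a slight lean towards a lower number.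

The estimated step is a 1.4-fold lower number from compound 3 to compound 4 (0.15 log units; within the scatter), and it is expected to remain within the scatter. For compound 4 the estimated value is 8500 nM, with an expected range of 3500 nM to 20000 nM.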

Compound 4, half-maximal cytotoxic concentration: 10300 nM
Compound 4: middle estimate off by 1.2-fold (0.08 log units), on the low side, within the range that was stated.
By their numbers in this assay, from the lowest: compound 2; then compounds 4, 1 and 3 (each within the scatter of the next).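

In this assay, the first case at this amine nitrogen in which the group attached through a methyl carbon rather than a carbonyl gives a 1.2-fold lower number from compound 3 to compound 4 (0.06 log units; within the scatter), so swapping ((methoxycarbonyl)methyl)carbonyl for its same-atom counterpart ((methoxycarbonyl)carbonyl)methyl gives no readable change. The same holds against the acetyl group, with a 1.0-fold lower number from compound 1 to compound 4 (0.02 log units; within the scatter), so a carbonyl directly on the amine nitrogen is not needed for the number to stay level with those of compound 1 and compound 3, while the carbamoyl group of compound 2 remains the one exception, with a 2.8-fold higher number from compound 2 to compound 4 (0.44 log units; beyond the scatter), a modest step beyond the scatter. No supporting measurement bears on why these numbers fall as they do.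

Open, from the compounds shown here alone, is whether the lower number of compound 2 belongs to carbamoyl alone or would also appear with a methylcarbamoyl group or a free amine at this nitrogen. Also open, going by these compounds, is whether a carboxylic acid in place of the methyl ester, or a longer chain between it and the amine nitrogen, would stay level with compound 3 and compound 4 in this assay.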